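Methylamino in Place of Chloro on a Dichlorinated Core

A few compounds are considered here, and "the series" means these few. Any claim that something is new, unique, unknown or untested is made for them only; others in the source may bear on it.

Compound 1 `OCC(CO)OCn1c(Cl)nc2c(Cl)c(Cl)ccc21` was tested in a functional assay on KB cells (Homo sapiens) for inhibition; a higher number here means a weaker inhibitor, a lower number a stronger inhibitor. In this assay compound 1 gives only a limit, > 100000 nM, and not a number. Two related compounds were measured alongside it. Compound 2 `CNc1nc2cc(Cl)c(Cl)cc2n1COC(CO)CO` also reaches only a limit in this assay, > 100000 nM. Compound 3 `CN(C)c1nc2cc(Cl)c(Cl)cc2n1COC(CO)CO` likewise gives a limit in this assay, > 100000 nM. For the measured compounds named here, the one step that joins measured compounds, from compound 2 to compound 3, is a step that the two limits leave unreadable from compound 2 to compound 3, so its size cannot be read. All three values sit at the same limit (the limit of > 100000 nM in this assay, at which 3 of the 3 values shown sit).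

Compound 4 `CNc1nc2c(Cl)c(Cl)ccc2n1COC(CO)CO` differs from compound 1 by methylamino in place of chloro on an aromatic carbon. Going by the values given here, no measured step covers this change; the step from compound 2 to compound 3 concerns a methyl on a nitrogen and is unreadable in any case. Compound 4 carries the same methylamino group as compound 2, on a core whose two chloro groups stand differently. With every measured value at a limit (the limit of > 100000 nM in this assay, at which 3 of the 3 values shown sit), nothing sets a size or a direction for the change from compound 1 to compound 4 in this assay. Compound 4 is therefore expected to give 150000 nM, with a range from 30000 nM to 1000000 nM, most likely again as a limit. The step this estimate means, from compound 1 to compound 4, is expected to be a step that the limit leaves unreadable from compound 1 to compound 4.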

Compound 4, half-maximal inhibitory concentration: > 100000 nM
Compound 4 gave a limit, no number; the forecaster's own chance of this, stated with the estimate: 85%; the middle value lies beyond the limit too.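

Compound 1 and compound 4 each give only a limit and not a number in this assay, so the change from chloro to methylamino yields no readable step: the limit of > 100000 nM in this assay, at which 4 of the 4 values shown sit.

The compounds shown leave open how strongly any of them inhibits in this assay, and whether methylamino in place of chloro changes that at all.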